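The source may hold more compounds than are shown below. What is called first, only, known or untested is meant among the compounds shown, and "the series" means these compounds.

Measured so far:
- compound 1 `COc1cc2oc(-c3cccc(NC(=O)c4ccc(C#N)cc4)c3)cc(=O)c2c(OC)c1OC` gives 10200 nM
- compound 2 `COc1cc2oc(-c3cccc(NC(=O)c4ccc(C(F)(F)F)cc4)c3)cc(=O)c2c(OC)c1OC` gives 61100 nM

In a functional assay on HepG2 cells (Homo sapiens) for inhibition, read by MTT assay (on this read-out lower numbers stand for stronger inhibition of growth and higher numbers for weaker inhibition of growth), compound 1 holds the lower of the two numbers, at 10200 nM against the higher one of compound 2. Compound 3 `COc1ccccc1C(=O)Nc1cccc(-c2cc(=O)c3c(OC)c(OC)c(OC)cc3o2)c1` has not been measured. It differs from compound 1 as follows: 2-methoxyphenyl in place of 4-cyanophenyl on a carbonyl carbon. Within the data shown here, only one measured step bears on this, a 6.0-fold higher number from compound 1 to compound 2 (0.78 log units; beyond the scatter), where trifluoromethyl replaces cyano on an aromatic carbon. It is modest, and it is a single precedent for a different change, so a step of similar modest size towards a higher number is expected. The expected change is a 2.5-fold higher number from compound 1 to compound 3 (0.39 log units; beyond the scatter). For compound 3 the estimate is 25000 nM, with an expected range from 7000 nM to 85000 nM.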

Compound 3, concentration for 50% growth inhibition: 7530 nM
The estimate for compound 3 lay 3.3-fold (0.52 log units) above the measured number; the range from low to high includes it.
By their numbers in this assay, from the lowest: compounds 3 and 1 (each within the scatter of the next); then compound 2.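

In this assay, the group on the carbonyl carbon could change from 4-cyanophenyl to 2-methoxyphenyl with a 1.4-fold lower number from compound 1 to compound 3 (0.13 log units; within the scatter). The step from 4-(trifluoromethyl)phenyl to 2-methoxyphenyl, by contrast, gives an 8.1-fold lower number from compound 2 to compound 3 (0.91 log units; beyond the scatter). The earlier step therefore does not hold for every replacement of 4-cyanophenyl: among these three compounds, only the 4-(trifluoromethyl)phenyl group of compound 2 stands apart. No evidence at hand accounts for this difference between the groups. As far as these compounds go, it remains open whether an amine or a carboxylic acid in place of the methoxy group of compound 3 would keep the number at this level.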